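This account rests on a few compounds, and the source may have more. Where it says the series, first, only, none or still open, it means among the compounds named here.

Compound 1 `COc1ccccc1/C=c1\c(=O)[nH]/c(=C/c2ccccc2Cl)c(=O)n1C` and compound 3 `COc1ccccc1/C=c1/[nH]c(=O)/c(=C\c2nc[nH]c2C(C)(C)C)[nH]c1=O` anchor this set: in a functional assay on HeLa cells (Homo sapiens) for cytotoxicity, read by CCK-8 assay, with a stated time of 72 h (on this read-out lower numbers stand for stronger inhibition and higher numbers for weaker inhibition), compound 1 gives 300 nM, and in this assay compound 3 gives 80 nM. Compound 2 `C=CCn1c(=O)/c(=C\c2ccc(F)c(Br)c2)[nH]c(=O)/c1=C\c1ccccc1OC` stands apart, since in this assay compound 2 is reported as "not active" (no number reported) and no single number is given for it, so its standing on the scale is known only as lying outside the range where the other two compounds have numbers.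

Compound 4 `C=CCn1c(=O)/c(=C\c2cccc(Cl)c2Cl)[nH]c(=O)/c1=C\c1ccccc1OC` is the one still to be measured. It differs from compound 2 in one place 2,3-dichlorophenyl in place of 3-bromo-4-fluorophenyl on a double-bonded chain carbon bound to an aromatic carbon while keeping the rest of the core of compound 2 unchanged.

For the measured compounds named here, no measured step between compound 2 and compound 4 exists, so the direction rests only on the fact that compound 1 carries a chloro-substituted aryl at the corresponding position and gives a number. Compound 4 is therefore expected to move toward stronger inhibition than compound 2, although with a real chance that it too is reported only as inactive. Compound 4 is estimated at 3000 nM, within 300 nM to 30000 nM.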

Compound 4, half-maximal inhibitory concentration: 1600 nM
The estimate for compound 4 lay 1.9-fold (0.27 log units) above the measured number; measured number inside the range.
By their numbers in this assay, from the lowest: compound 3; then compound 1; then compound 4.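

For the compounds shown here, compound 2 is reported without a number in this assay and compound 4 gives 1600 nM, so no step between them can be read. The compounds shown leave open how far 2,3-dichlorophenyl in place of 3-bromo-4-fluorophenyl itself shifts inhibition. Nothing shown bears on a cause for this result.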